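Chloro addition on the urea aryl of compound 1

A few compounds are considered here, and "the series" means these few. Any claim that something is new, unique, unknown or untested is made for them only; others in the source may bear on it.

Going by the values given here, compound 1 `O=C(Nc1cccc(-n2cc(-c3ccncc3)c(-c3ccc(Cl)c(O)c3)n2)c1)Nc1cccc(C(F)(F)F)c1` is the weaker of the two measured members: in a functional assay on SF-295 cells (Homo sapiens) for inhibition, read by sulforhodamine B assay, with a stated time of 48 h (a lower number here means a stronger inhibitor of growth, a higher number a weaker inhibitor of growth), compound 1 gives 4260 nM. Among the compounds with values here, its only neighbour is compound 2 `COc1cc(-c2nn(-c3cccc(NC(=O)Nc4cccc(C(F)(F)F)c4)c3)cc2-c2ccncc2)ccc1Cl`, which in this assay gives 1130 nM; the step of a 3.8-fold lower number from compound 1 to compound 2 (0.58 log units; beyond the scatter) is the single step recorded so far. Compound 3 `O=C(Nc1cccc(-n2cc(-c3ccncc3)c(-c3ccc(Cl)c(O)c3)n2)c1)Nc1ccc(Cl)c(C(F)(F)F)c1` differs from compound 1 in a different part of the structure: chloro in place of hydrogen on an aromatic carbon, ortho to the trifluoromethyl group and para to a large group, so that the 3-(trifluoromethyl)phenyl becomes a 4-chloro-3-(trifluoromethyl)phenyl. Within the data shown here, no measured step touches this aryl; the one step available, from compound 1 to compound 2, alters the phenol oxygen and says nothing direct about a chloro entering here. The expectation therefore rests only on the size of that step as a guide to how much a single small change moves this series: a shift of comparable or smaller size, in either direction, is considered plausible. Compound 3 is expected at 2800 nM in this assay, within 900 nM to 8000 nM. The expected step of a 1.5-fold lower number from compound 1 to compound 3 (0.18 log units; within the scatter) is thus small and uncertain.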

Compound 3, concentration for total growth inhibition: 2060 nM
Beside the measured number, compound 3's estimate is 1.4-fold (0.13 log units) above it; measured number inside the range.
By their numbers in this assay, from the lowest: compounds 2 and 3 (each within the scatter of the next); then compound 1.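

In this assay, going by these compounds alone, chloro in place of hydrogen on the 3-(trifluoromethyl)phenyl gives a 2.1-fold lower number from compound 1 to compound 3 (0.32 log units; beyond the scatter) and is the first reading on this aryl of the urea: this aromatic carbon takes a chloro with no loss of growth inhibition, and the change is a modest gain. The urea aryl is thus a second place on compound 1 where a single small change lowers the number beyond the scatter, alongside the methyl on the phenol oxygen with a 3.8-fold lower number from compound 1 to compound 2 (0.58 log units; beyond the scatter) as the earlier step. Nothing measured in the series bears on why the number moves at this position.

On these data alone, it remains open whether the lower number belongs to chloro itself or would follow other groups on the same aromatic carbon, such as fluoro, bromo, methoxy or an amine. Also open, as far as these compounds go, is whether the chloro and the methyl on the phenol oxygen would add up when both stand on the core of compound 1, as each is read here only alone.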